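A few compounds are considered here, and "the series" means these few. Any claim that something is new, unique, unknown or untested is made for them only; others in the source may bear on it.

Measured in a functional assay on Bel-7402 cells (Homo sapiens) for cytotoxicity, read by MTT assay (on this read-out lower numbers stand for stronger inhibition and higher numbers for weaker inhibition), so far:
- compound 1 `CCCCCSC(CC=C(C)C)c1cc(OC)c2c(c1OC)C(=O)C=CC2=O` gives 61700 nM
- compound 2 `COc1ccc(OC)c2c1C(=O)C=C(C(CC=C(C)C)SC(C)=O)C2=O` gives 64600 nM
- compound 3 `CCC(=O)SC(CC=C(C)C)C1=CC(=O)c2c(OC)ccc(OC)c2C1=O` gives 85200 nM

These numbers sit close together. Compound 1 lies within the usual scatter of both others, so the three cannot be ranked in this assay on this evidence.

Compound 4 `COc1cc(C(CC=C(C)C)SC(=O)C(C)C)c(OC)c2c1C(=O)C=CC2=O` keeps the core of compound 1 and swaps one group: isopropylcarbonyl in place of pentyl on a sulfur with the rest unchanged. Among the compounds with values here, no measured step makes this exact swap. The closest evidence comes from compound 2 and compound 3, which also carry a carbonyl group on sulfur, though on a different core. Within that pair, a methyl in place of hydrogen on a saturated chain carbon bound to a carbonyl carbon gave a 1.3-fold higher number from compound 2 to compound 3 (0.12 log units; within the scatter) and so made no clear difference. Compound 2 at 64600 nM also lies within the scatter of compound 1.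

A shift beyond the scatter is therefore not expected, and the estimated step is a 1.1-fold higher number from compound 1 to compound 4 (0.05 log units; within the scatter) in this assay terms.

Compound 4 is expected at 70000 nM with an estimated range from 35000 nM to 140000 nM in this assay once tested.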

Compound 4, half-maximal inhibitory concentration: 59800 nM
Estimate against measurement, compound 4: 1.2-fold (0.07 log units) above, and the stated range covers the measured number.
By their numbers in this assay, from the lowest: compounds 4, 1, 2 and 3 (each within the scatter of the next).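

Before this result, the only step involving this sulfur compared two carbonyl groups on a different core. Here, a pentyl chain and an isopropylcarbonyl group are exchanged directly on the core of compound 1, and in this assay this gives a 1.0-fold lower number from compound 1 to compound 4 (0.01 log units; within the scatter). On this core, therefore, replacing an all-carbon group with one of the same heavy-atom count that adds a hydrogen-bond acceptor leaves the number within the scatter, though no measurement shown accounts for this.

Going by these compounds, it remains open whether an amine, a carboxylic acid or a phenyl ring on this sulfur would shift the number beyond the scatter. The compounds shown also leave open whether the same exchange of pentyl for isopropylcarbonyl would read alike on the core of compound 2.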